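Swapping a pyrimidinyl for a benzyl on a piperazine

The source may report more compounds than this note shows. Statements on the series, on what has been measured and on what is new or still open speak of the compounds shown alone.

Measured compounds:
- compound 1, `NS(=O)(=O)Oc1ccc2c(c1)CN(C(=O)c1cccc(N3CCN(c4ncccn4)CC3)c1)CC2`: 24.4%
- compound 2, `CN(C)CCCN(Cc1ccccc1)c1ccc(C(=O)N2CCc3ccc(OS(N)(=O)=O)cc3C2)cc1`: 61.6%
- compound 3, `CCN(Cc1ccccc1)c1ccc(C(=O)N2CCc3ccc(OS(N)(=O)=O)cc3C2)cc1`: 83.6%

All three share a core carrying a sulfamate and were tested in an assay on HEK293 cells for inhibition of Steryl-sulfatase (Homo sapiens), tested at 1 uM; a lower number here means a weaker effect, a higher number a stronger effect of the compound at the concentration tested. Compound 1 gives the lowest of the three numbers: compound 2 sits well above it, and compound 3 further still, both gaps beyond the scatter.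

The unmeasured compound 4, `NS(=O)(=O)Oc1ccc2c(c1)CN(C(=O)c1cccc(N3CCN(Cc4ccccc4)CC3)c1)CC2`, differs from compound 1 in one place: benzyl in place of pyrimidin-2-yl on an amine nitrogen in a ring.

Going by the values given here, the only measured step, a number 22 percentage points higher from compound 2 to compound 3 (beyond the scatter), concerns a different change at a different place and does not bear directly on this swap. Compounds 2 and 3 do carry a benzyl group and reach the higher numbers, but they differ from compound 1 in several places at once, so they offer only a loose hint. For compound 4 a modest rise is therefore expected, a number 15.6 percentage points higher from compound 1 to compound 4 (beyond the scatter), with wide uncertainty. The estimate for compound 4 is 40%, within a range from 15% to 70%.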

Compound 4, a percentage reported as inhibition, at one concentration (the size of the read-out at that concentration, not a potency): 23.7%
Beside the measured number, compound 4's estimate is 16.3 percentage points above it, and the stated range covers the measured number.
By their numbers in this assay, from the lowest: compounds 4 and 1 (each within the scatter of the next); then compound 2; then compound 3.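

Benzyl in place of pyrimidin-2-yl on an amine nitrogen in a ring gives, in this assay, a number 0.7 percentage points lower from compound 1 to compound 4 (within the scatter). At this position, then, an aromatic ring of carbon only serves as well as one with 2 hetero atoms: compounds 1 and 4 stand within the scatter of each other, although the 2 hydrogen-bond acceptors counted in pyrimidin-2-yl are absent from benzyl. Nothing measured here gives a reason for this.

From the compounds shown here alone, whether this tolerance extends to other groups on the same nitrogen, such as a phenethyl chain, an acetyl group or a plain hydrogen, stays open. Also open, going by these compounds, is whether compounds 1 and 4 would still match at other concentrations, since a read-out at a single concentration is not a potency.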